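Fluoro in Place of Methoxy on the Urea Aryl Ring

A few compounds are considered here, and "the series" means these few. Any claim that something is new, unique, unknown or untested is made for them only; others in the source may bear on it.

Compound 3 `COc1ccc(NC(=O)Nc2cccc(CNc3ncnc4ccccc34)c2)cc1` gives 29300 nM in a functional assay on A549 cells (Homo sapiens) for antiproliferative activity, read by MTT assay (a higher number here means a weaker inhibitor, a lower number a stronger inhibitor), the lowest of the three numbers shown, though each of its steps to the other two lies within the scatter. Compound 1 `Cc1ccccc1NC(=O)Nc1cccc(CNc2ncnc3ccccc23)c1` gives 40200 nM and compound 2 `Cc1cccc(NC(=O)Nc2cccc(CNc3ncnc4ccccc34)c2)c1` gives 30200 nM in this assay. The steps of a 1.3-fold lower number from compound 1 to compound 2 (0.12 log units; within the scatter), a 1.4-fold lower number from compound 1 to compound 3 (0.14 log units; within the scatter) and a 1.0-fold lower number from compound 2 to compound 3 (0.01 log units; within the scatter) all fall within the scatter, so exchanging the aryl group on the urea nitrogen among these three compounds has moved nothing beyond it. Compound 4 `O=C(Nc1ccc(F)cc1)Nc1cccc(CNc2ncnc3ccccc23)c1` differs from compound 3 by fluoro in place of methoxy on an aromatic carbon. Among the compounds with values here, none of the measured steps tests a fluoro, but each of them bears on the same aryl ring of the urea, and each was flat; a like outcome is therefore expected for compound 4 in this assay, with no step beyond the scatter in either direction. For compound 4 the step of a 1.1-fold higher number from compound 3 to compound 4 (0.04 log units; within the scatter) is expected. Compound 4 is estimated at 32000 nM, with a range from 15000 nM to 70000 nM.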

Compound 4, half-maximal inhibitory concentration: 21000 nM
Beside the measured number, compound 4's estimate is 1.5-fold (0.18 log units) above it; low and high end bracket the measured number.
By their numbers in this assay, from the lowest: compounds 4, 3, 2 and 1 (each within the scatter of the next).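

Fluoro in place of methoxy on this aromatic carbon, para to a large group, gives a 1.4-fold lower number from compound 3 to compound 4 (0.14 log units; within the scatter) in this assay, so here the aryl ring of the urea also accepts a halogen without a step beyond the scatter. Set against the two methylphenyl compounds, 4-fluorophenyl gives a 1.4-fold lower number from compound 2 to compound 4 (0.16 log units; within the scatter) and a 1.9-fold lower number from compound 1 to compound 4 (0.28 log units; within the scatter), which extends the flat picture from three aryl groups to four. No measurement at hand explains why this position stays so flat.

The compounds shown leave open whether an amine, a carboxylic acid or a longer chain on this ring would move the number beyond the scatter. They also leave open whether fluoro at another carbon of the ring, or a second fluoro, would do so.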